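A few compounds are considered here, and "the series" means these few. Any claim that something is new, unique, unknown or untested is made for them only; others in the source may bear on it.

Going by the values given here, compound 2 `C[C@@H]1CCCN1c1c(C#N)c2c(N)nc(Nc3cn[nH]c3)nc2n1C` gives 6 nM in an assay on isolated protein for inhibition of Leucine-rich repeat serine/threonine-protein kinase 2 variant G2019S (Homo sapiens), read by TR-FRET and LanthaScreen, with stated times of 50 min and 30 min, in the presence of a further agent that is not named here (a higher number here means a weaker inhibitor, a lower number a stronger inhibitor), the lower of the two numbers so far; compound 1 `C[C@@H]1CCCN1c1c(C#N)c2c(N)nc(Nc3cn(C)nc3C(F)(F)F)nc2n1C` gives 358 nM, and the step of a 60-fold lower number from compound 1 to compound 2 (1.78 log units; beyond the scatter) is large. Compound 3 `Cc1c(Nc2nc(N)c3c(C#N)c(N4CCC[C@H]4C)n(C)c3n2)cnn1C1COC1` carries a substituted pyrazole instead: 5-methyl-1-(oxetan-3-yl)-1H-pyrazol-4-yl in place of 1H-pyrazol-4-yl on a nitrogen on an aromatic ring. Among the compounds with values here, the one measured step bears on it, since removing the substituents on the pyrazole of compound 1 gave the large drop to compound 2; reinstating substitution on this ring, with a different set, is therefore expected to raise the number again, though not necessarily by the same amount. For compound 3 the expected step is a 10-fold higher number from compound 2 to compound 3 (1.00 log units; beyond the scatter), so compound 3 is estimated at 60 nM, within 15 nM to 250 nM.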

Compound 3, half-maximal inhibitory concentration: 37 nM
Compound 3: middle estimate off by 1.6-fold (0.21 log units), on the high side; the range from low to high includes it.
By their numbers in this assay, from the lowest: compound 2; then compound 3; then compound 1.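

In this assay, the pyrazole on this nitrogen tolerates substitution with a smaller penalty than compound 1 indicated: the cost is a 6.2-fold higher number from compound 2 to compound 3 (0.79 log units; beyond the scatter), while changing the substituents alone gives a 9.7-fold lower number from compound 1 to compound 3 (0.99 log units; beyond the scatter). The substituent set therefore matters, not merely the presence of substitution, although the unsubstituted 1H-pyrazol-4-yl of compound 2 still gives the lowest number. No evidence on hand accounts for either step.

The 5-methyl and oxetan-3-yl groups enter together, so their separate contributions remain unresolved. Going by these compounds, how a piperidine or a carboxylic acid on the pyrazole would fare also remains open.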